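Replacing 3-oxomorpholin-4-yl in compound 2

The compounds below may be only part of what the source reports. "The series", "measured", "known", "first", "only" and "open" are said of these compounds alone.

Measured in an ADME assay on microsomes from liver (Homo sapiens) for metabolic stability, with a stated time of 10 min; on this read-out higher numbers stand for a more stable compound and lower numbers for a less stable compound:
Compound 1 `COc1cc(OCc2csc(-c3cccc(C(=O)N(C)C)c3)n2)c2cc(-c3cn4nc(OC)sc4n3)oc2c1`: 63%
Compound 2 `COc1cc(OCc2csc(N3CCOCC3=O)n2)c2cc(-c3cn4nc(OC)sc4n3)oc2c1`: 54%

Compound 2, at 54%, stands within the scatter of compound 1. Compound 3 `COc1cc(OCc2csc(-c3ccc(OC)nc3)n2)c2cc(-c3cn4nc(OC)sc4n3)oc2c1` carries 6-methoxypyridin-3-yl in place of 3-oxomorpholin-4-yl on an aromatic carbon. Going by the values given here, only one measured step bears on this place, a number 9 percentage points lower from compound 1 to compound 2 (within the scatter), where a 3-(dimethylcarbamoyl)phenyl group gave way to the same 3-oxomorpholin-4-yl. Among the compounds with values here, with so small a step as the only guide, the expected change is a number 4 percentage points higher from compound 2 to compound 3 (within the scatter), nothing beyond the scatter. Compound 3 is estimated at 58%, within a range of 40% to 75%.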

Compound 3, percent of the compound remaining: 76%
The estimate for compound 3 lay 18 percentage points below the measured number; the whole stated range lies below it.
By their numbers in this assay, from the lowest: compounds 2 and 1 (each within the scatter of the next); then compound 3.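

In this assay, the change to 6-methoxypyridin-3-yl gives a number 22 percentage points higher from compound 2 to compound 3 (beyond the scatter) and a number 13 percentage points higher from compound 1 to compound 3 (beyond the scatter) on the same aromatic carbon. Going by these compounds alone, compound 1 and compound 2 lay within the scatter of each other, so this position now shows a difference beyond the scatter for the first time, and compound 3 stands highest of the three. Nothing measured here accounts for this rise.

From the compounds shown here alone, it remains open whether the methoxy group or the ring nitrogen of the pyridine matters more. A plain phenyl or an amine at this place would help to separate these possibilities.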